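A few compounds are considered here, and "the series" means these few. Any claim that something is new, unique, unknown or untested is made for them only; others in the source may bear on it.

Compound 1 `Cc1cc(Nc2cc(N3CCN(C)CC3)nc(Nc3ccc(S(N)(=O)=O)cc3)n2)n[nH]1`: 4380 nM
Compound 2 `Cc1cc(Nc2cc(N3CCN(C)CC3)nc(Nc3cccc(Cl)c3)n2)n[nH]1`: 573 nM
Compound 3 `COc1ccc(Nc2nc(Nc3cc(C)[nH]n3)cc(N3CCN(C)CC3)n2)cc1`: not yet measured

In a functional assay on PC-3 cells (Homo sapiens) for antiproliferative activity, read by CCK-8 assay, with a stated time of 72 h (a higher number here means a weaker inhibitor, a lower number a stronger inhibitor), compound 2 has the lower of the two numbers. Compound 3 carries 4-methoxyphenyl in place of 3-chlorophenyl on a nitrogen on an aromatic ring. Within the data shown here, the only measured step at this place is a 7.6-fold lower number from compound 1 to compound 2 (0.88 log units; beyond the scatter), a modest step. It is a single step with a different group, so it gives only a rough guide. A smaller move back towards a higher number is expected, and the expected step is a 2.1-fold higher number from compound 2 to compound 3 (0.32 log units; beyond the scatter). Compound 3 is estimated at 1200 nM, with an expected range of 350 nM to 4000 nM.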

Compound 3, half-maximal inhibitory concentration: 2000 nM
Compound 3: middle estimate off by 1.7-fold (0.22 log units), on the low side, and the stated range covers the measured number.
By their numbers in this assay, from the lowest: compound 2; then compound 3; then compound 1.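

In this assay, the change from 3-chlorophenyl to 4-methoxyphenyl on this nitrogen gives a 3.5-fold higher number from compound 2 to compound 3 (0.54 log units; beyond the scatter) and leaves 3-chlorophenyl with the lowest number of the three aryl groups. Methoxy in place of sulfamoyl on an aromatic carbon gives a 2.2-fold lower number from compound 1 to compound 3 (0.34 log units; beyond the scatter) and places compound 3 between the other two. Nothing measured here explains these differences.

The step from compound 2 to compound 3 changes both the substituent and its place on the phenyl ring, and the compounds shown cannot separate the two. As far as these compounds go, how an unsubstituted phenyl or a nitrile-bearing phenyl would compare on this nitrogen remains open.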